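The compounds below may be only part of what the source reports. "The series", "measured", "known", "first", "only" and "open" are said of these compounds alone.

The compounds measured so far:
compound 1, `Nc1sc(-c2ccc(Cl)cc2)c(-c2ccc(Cl)cc2)c1C(=O)NC1CCCCC1`, gives 2410 nM in a functional assay on A549 cells (Homo sapiens) for inhibition, read by sulforhodamine B assay, with a stated time of 72 h; on this read-out higher numbers stand for weaker inhibition and lower numbers for stronger inhibition.
compound 2, `Nc1sc(-c2ccc(Cl)cc2)c(-c2ccc(Cl)cc2)c1C(=O)NC1CCCC1`, gives 6790 nM.
compound 3, `Nc1sc(-c2ccc(Cl)cc2)c(-c2ccc(Cl)cc2)c1C(=O)N1CCCCC1=O`, gives 1820 nM.

Compound 1 stands second highest of these three numbers. Its nearest neighbour is given by a 1.3-fold lower number from compound 1 to compound 3 (0.12 log units; within the scatter), which lies within the scatter; the furthest by a 2.8-fold higher number from compound 1 to compound 2 (0.45 log units; beyond the scatter), which lies beyond it.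

Compound 4, `Nc1sc(-c2ccc(Cl)cc2)c(-c2ccc(Cl)cc2)c1C(=O)N1CCOCC1`, differs from compound 1 in one place: morpholin-4-yl in place of cyclohexylamino on a carbonyl carbon. For the measured compounds named here, two measured steps bear on this change. The first is the one in which 2-oxopiperidin-1-yl took the place of cyclohexylamino on the carbonyl carbon, a 1.3-fold lower number from compound 1 to compound 3 (0.12 log units; within the scatter), a shift inside the scatter. The second is the one in which 2-oxopiperidin-1-yl took the place of cyclopentylamino, a 3.7-fold lower number from compound 2 to compound 3 (0.57 log units; beyond the scatter), a modest lowering. Both show that a cyclic group bound through its nitrogen on the carbonyl carbon is tolerated at least as well as a cyclohexylamino group. A step of no more than scatter size is therefore expected from compound 1 to compound 4, a 1.1-fold higher number from compound 1 to compound 4 (0.03 log units; within the scatter). For compound 4 the value in this assay is estimated at 2600 nM, with a range from 1100 nM to 6500 nM.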

Compound 4, half-maximal inhibitory concentration: 1870 nM
Estimate against measurement, compound 4: 1.4-fold (0.14 log units) above; low and high end bracket the measured number.
By their numbers in this assay, from the lowest: compounds 3, 4 and 1 (each within the scatter of the next); then compound 2.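

Morpholin-4-yl on the carbonyl carbon, with a ring oxygen and no amide hydrogen, gives a 1.3-fold lower number from compound 1 to compound 4 (0.11 log units; within the scatter), so in this assay this change from cyclohexylamino leaves the number within the scatter. The ring carbonyl of 2-oxopiperidin-1-yl is thus not needed to hold the number at this level, since replacing that group with morpholin-4-yl gives a 1.0-fold higher number from compound 3 to compound 4 (0.01 log units; within the scatter), and compound 2 stays apart, with cyclopentylamino exchanged for morpholin-4-yl giving a 3.6-fold lower number from compound 2 to compound 4 (0.56 log units; beyond the scatter). No measurement shown here accounts for why these three different groups on the carbonyl carbon give such similar numbers.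

The compounds shown leave open whether a second ring nitrogen, as in piperazin-1-yl, or an open-chain group such as diethylamino on the carbonyl carbon would stay level with compound 1, compound 3 and compound 4. They also leave open whether this tolerance holds once a carboxylic acid or a longer chain is carried on the ring attached through its nitrogen, since all four compounds share the same core and none of their groups on the carbonyl carbon carries such a substituent.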